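This account rests on a few compounds, and the source may have more. Where it says the series, first, only, none or still open, it means among the compounds named here.

Compound 1 `COc1ccc(-c2ss/c(=N/O)c2-c2cc(OC)c(OC)c(OC)c2)cc1O` gives 200 nM.
Compound 2 `COc1ccc(-c2c(-c3cc(OC)c(OC)c(OC)c3)ss/c2=N/O)cc1[N+](=O)[O-]` gives 6560 nM.
Compound 3 `CO/N=c1/ssc(-c2ccc(OC)c(O)c2)c1-c1cc(OC)c(OC)c(OC)c1` gives 10000 nM.

All three were tested in a functional assay on SGC-7901 cells (Homo sapiens) for antiproliferative activity, read by MTT assay, with a stated time of 72 h; on this read-out higher numbers stand for weaker inhibition and lower numbers for stronger inhibition. The difference between the cores of compound 1 and compound 2 is not broken down here. Compound 3 differs from compound 1 in one place only: methyl in place of hydrogen on an oxygen. That single change produced the step of a 50-fold higher number from compound 1 to compound 3 (1.70 log units; beyond the scatter), so the methylated compound inhibits cell growth far less strongly.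

Compound 4 `CO/N=c1/ssc(-c2cc(OC)c(OC)c(OC)c2)c1-c1ccc(OC)c([N+](=O)[O-])c1` has not yet been measured in this assay. It differs from compound 2 by methyl in place of hydrogen on an oxygen, the same change at the same place as the one seen before. If that change acts alike on the core of compound 2, the expected step is a 6.1-fold higher number from compound 2 to compound 4 (0.79 log units; beyond the scatter). This expectation rests on the earlier step of a 50-fold higher number from compound 1 to compound 3 (1.70 log units; beyond the scatter). Compound 4 is therefore estimated at 40000 nM, most likely between 10000 nM and 150000 nM.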

Compound 4, half-maximal inhibitory concentration: > 100000 nM
Compound 4: no number, only a limit (the forecaster's own chance of this, stated with the estimate: 35%); at least 2.5-fold (0.39 log units) between middle value and limit.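

In this assay compound 4 gives > 100000 nM, which is a limit of the assay and not an exact number. Methyl in place of hydrogen on this oxygen gives an at least 15-fold higher number from compound 2 to compound 4 (1.18 log units; beyond the scatter), so the change weakens inhibition on both cores and its direction carries over. Whether its size also carries over stays unsettled: the same change on two cores in this assay, a 50-fold higher number (1.70 log units; beyond the scatter) from compound 1 to compound 3 and an at least 15-fold higher number (1.18 log units; beyond the scatter) from compound 2 to compound 4; the limit leaves it open whether they differ

The compounds shown leave open how a longer chain, such as ethyl, or an amine-bearing chain on the same oxygen would compare with hydrogen and methyl. They also leave open whether the same direction would hold on any further core.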